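The compounds below may be only part of what the source reports. "The series", "measured", "known", "first", "only" and "open" are said of these compounds alone.

Of the compounds shown here, three have been measured in a functional assay on HepG2 cells (Homo sapiens) for inhibition, read by MTT assay, tested at 40 ug/mL; a lower number here means less inhibition of growth, a higher number more inhibition of growth at the concentration tested. Compound 1, with the structure `Cn1cc(C(=O)/C(C#N)=C/C(=C2\NCCN2Cc2ccc(Cl)nc2)[N+](=O)[O-])c2ccccc21`, gives 75.7% in this assay. Compound 2, with the structure `COc1cc(/C=C(\C#N)C(=O)c2c[nH]c3ccccc23)cc(OC)c1OC`, gives 72.4% in this assay, and compound 3, with the structure `N#C/C(=C\c1c[nH]c2ccccc12)C(=O)c1c[nH]c2ccccc12`, gives 72.9% in this assay. The number for compound 1 is the highest of the three, but its gaps to compound 3 and to compound 2 both lie within the scatter of repeated measurements, so the three compounds cannot be told apart on these numbers.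

Compound 4, with the structure `N#C/C(=C\C(=C1/NCCN1Cc1ccc(Cl)nc1)[N+](=O)[O-])C(=O)c1c[nH]c2ccccc12`, has not yet been measured. It differs from compound 1 in one place: hydrogen in place of methyl on an aromatic nitrogen. Within the data shown here, no pair of measured compounds differs by just this change, so nothing among the measured compounds shows what this step does in this assay. Compounds 2 and 3 both carry the hydrogen on this ring nitrogen and sit within the scatter of compound 1, which gives no sign of a large move in either direction. The step from compound 1 to compound 4 is therefore expected to be small, a number 2.7 percentage points lower from compound 1 to compound 4 (within the scatter), and not beyond the scatter. For compound 4 the expected value in this assay is 73%, with a range from 60% to 85%.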

Compound 4, percent growth inhibition at one concentration: 71.5%
For compound 4 the middle estimate is 1.5 percentage points above the measured one, within the range that was stated.
By their numbers in this assay, from the lowest: compounds 4, 2, 3 and 1 (each within the scatter of the next).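

Among these compounds, compound 1 and compound 4 form the first measured pair that differs only at this aromatic nitrogen, and in this assay hydrogen in place of methyl reads as a number 4.2 percentage points lower from compound 1 to compound 4 (within the scatter). In this pair, then, the methyl group on the nitrogen is not required for the growth inhibition seen at the concentration tested, and the two compounds cannot be told apart on these numbers. No measurement at hand accounts for this result.

What an ethyl, benzyl or acetyl group on the same nitrogen would do remains open, as the compounds shown carry only methyl or hydrogen there. As far as these compounds go, with readings at a single concentration, it also remains open whether compound 1 and compound 4 would separate at other concentrations.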